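From Amino to Phenyl on a Saturated Ring Carbon

The source may report more compounds than this note shows. Statements on the series, on what has been measured and on what is new or still open speak of the compounds shown alone.

compound 1 `CN(c1ccc2cc(NC(=O)CCc3ccc(C(F)(F)F)cc3)ccc2n1)C1CCCCC1`: 1200 nM
compound 2 `NC1CCN(c2ccc3cc(NC(=O)CCc4ccc(C(F)(F)F)cc4)ccc3n2)C1`: 200 nM

Within the data shown here, in a functional assay on HEK293 cells for activation of melanin-concentrating hormone receptor 1 (Rattus norvegicus), read by inositol phosphate accumulation (on this read-out higher numbers stand for an effect only at larger amounts of compound and lower numbers for an effect already at smaller amounts), compound 2 gives 200 nM, the lower of the two numbers measured so far, and the step of a 6.0-fold lower number from compound 1 to compound 2 (0.78 log units; beyond the scatter) separates it from compound 1, which gives 1200 nM. Compound 3 `O=C(CCc1ccc(C(F)(F)F)cc1)Nc1ccc2nc(N3CCC(c4ccccc4)C3)ccc2c1` differs from compound 2 by phenyl in place of amino on a saturated ring carbon. Among the measured compounds shown here, the one measured step swapped the whole amine group and does not cover this exchange, so no direct guide exists. A step of a 3.0-fold higher number from compound 2 to compound 3 (0.48 log units; beyond the scatter) toward a higher number is expected, only tentatively. For compound 3 the estimate is 600 nM, between 150 nM and 2500 nM.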

Compound 3, half-maximal effective concentration: 1770 nM
Beside the measured number, compound 3's estimate is 3.0-fold (0.47 log units) below it; low and high end bracket the measured number.
By their numbers in this assay, from the lowest: compound 2; then compounds 1 and 3 (each within the scatter of the next).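

In this assay, the amino group on this saturated ring carbon does not tolerate exchange for phenyl: the swap gives an 8.9-fold higher number from compound 2 to compound 3 (0.95 log units; beyond the scatter) and loses what compound 2 had gained. The 3-phenylpyrrolidin-1-yl group of compound 3 and the cyclohexyl(methyl)amino group of compound 1 cannot be told apart, at a 1.5-fold higher number from compound 1 to compound 3 (0.17 log units; within the scatter), so a 3-substituted pyrrolidin-1-yl group alone does not bring the lower number. On these data alone, it remains open whether a smaller group on that carbon, such as hydroxyl, methyl or aminomethyl, would keep the number of compound 2. Nothing available here explains why phenyl and amino differ so much.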